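Amide-bound aryl exchange in a rhodanine-type cytotoxicity series

The compounds below may be only part of what the source reports. "The series", "measured", "known", "first", "only" and "open" are said of these compounds alone.

Among the compounds with values here, compound 2 `O=C(CN1C(=O)/C(=C/c2ccc(-c3ccc(Cl)cc3)o2)SC1=S)NCc1ccc(F)cc1` stands at the lower end of the two numbers so far: in a functional assay on K562 cells (Homo sapiens) for cytotoxicity, read by MTT assay, with a stated time of 72 h (a lower number here means a stronger inhibitor, a higher number a weaker inhibitor), compound 2 gives 150000 nM, and compound 1 `O=C(CN1C(=O)/C(=C/c2ccc(-c3ccc(Cl)cc3)o2)SC1=S)NCc1ccc(C(F)(F)F)cc1` gives 155000 nM. Within the data shown here, the only measured step, a 1.0-fold lower number from compound 1 to compound 2 (0.01 log units; within the scatter), changes a substituent on the aromatic ring of the benzyl group and leaves the potency unchanged within the scatter. Compound 3 `N#Cc1cc(NC(=O)CN2C(=O)/C(=C/c3ccc(-c4ccc(Cl)cc4)o3)SC2=S)ccc1C(F)(F)F` differs from compound 2 in a larger way: 3-cyano-4-(trifluoromethyl)phenyl in place of 4-fluorobenzyl on an amide-type nitrogen. The measured step bears on this change only in part, since it too concerns the aromatic group on the amide-type nitrogen and swaps fluoro against trifluoromethyl, yet it did not move the number. Among the measured compounds shown here, nothing else speaks to exchanging a benzyl for a substituted phenyl at that nitrogen, so the expectation rests on the one flat step. Compound 3 is therefore expected to stay close to compound 2, with a step of no change at the digits printed from compound 2 to compound 3 (within the scatter) that is not expected to exceed the scatter. The estimate for compound 3 in this assay is 150000 nM, within a range from 60000 nM to 400000 nM.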

Compound 3, half-maximal inhibitory concentration: > 250000 nM
Compound 3 gave a limit, no number; the forecaster's own chance of this, stated with the estimate: 20%; at least 1.6-fold (0.22 log units) between middle value and limit.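

In this assay, the reading for compound 3 is a limit of the assay and not a number: the limit of > 250000 nM in this assay, at which 1 of the 3 values shown sits.

The exchange on the amide-type nitrogen, a larger change than the fluoro for trifluoromethyl swap seen earlier, gives an at least 1.6-fold higher number from compound 2 to compound 3 (0.22 log units; that floor lies within the scatter) and an at least 1.6-fold higher number from compound 1 to compound 3 (0.20 log units; that floor lies within the scatter). Both floors stay within the scatter, so the result does not establish a loss of potency, but it does show that replacing either benzyl group with 3-cyano-4-(trifluoromethyl)phenyl gives no stronger inhibitor at this position and takes the reading out of the range where the assay returns a number.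

Three things changed together in this exchange, the benzyl becoming a phenyl and the nitrile and trifluoromethyl groups being set on the new ring, and the compounds shown cannot separate their contributions. On these data alone, it remains open whether a phenyl carrying only the nitrile or only the trifluoromethyl would return a number, and whether an amine or a carboxylic acid on the aromatic ring would move the reading at all.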